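The compounds below may be only part of what the source reports. "The series", "measured", "known", "first", "only" and "open" are said of these compounds alone.

Compound 1, `CCOC(=O)C1=C(Nc2ccccc2)S/C(=C\c2ccc[nH]2)C1=O`, is the starting point. In a functional assay on K562 cells (Homo sapiens) for inhibition, read by MTT assay, with a stated time of 72 h (a lower number here means a stronger inhibitor, a higher number a weaker inhibitor), compound 1 gives 71000 nM. This is the only number shown in this assay; the other value is a limit. Compound 2, `CCOC(=O)C1=C(Nc2cccc(C(F)(F)F)c2)S/C(=C\c2ccc[nH]2)C1=O`, carries a trifluoromethyl in place of hydrogen on an aromatic carbon. For compound 2, this assay reports only a limit, > 100000 nM. Going by the values given here, the step of an at least 1.4-fold higher number from compound 1 to compound 2 (0.14 log units; that floor lies within the scatter) therefore rests on that limit, and its floor lies within the scatter; the sole evidence behind it is the limit of > 100000 nM in this assay, at which 1 of the 2 values shown sits.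

Compound 3, `CCOC(=O)C1=C(Nc2ccccc2)S/C(=C\c2ccc(C(=O)OCC)[nH]2)C1=O`, differs from compound 1 at a different place: ethoxycarbonyl in place of hydrogen on an aromatic carbon. Among the compounds with values here, the one measured step alters the other aromatic ring, so it cannot be carried over directly; it shows only that one change to the core of compound 1 did not lower the number. For compound 3 no step beyond the scatter is expected in this assay, with the direction left open. Compound 3 is estimated at 80000 nM in this assay, within 30000 nM to 200000 nM. The expected step of a 1.1-fold higher number from compound 1 to compound 3 (0.05 log units; within the scatter) should stay within the scatter.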

Compound 3, half-maximal inhibitory concentration: 46800 nM
The estimate for compound 3 lay 1.7-fold (0.23 log units) above the measured number; the measured number falls inside the stated range.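

The change gives a 1.5-fold lower number from compound 1 to compound 3 (0.18 log units; within the scatter) in this assay, so at this position, on an aromatic carbon of the five-membered aromatic ring with 1 nitrogen and next to the ring nitrogen, ethoxycarbonyl and hydrogen cannot be told apart in this read-out. Going by these compounds alone, the earlier pair altered only the other aromatic ring, so this is the first reading from this ring, and it shows that a group of 5 heavy atoms can stand at this carbon without a step beyond the scatter. No information shown bears on why this position behaves in this way.

From the compounds shown here alone, it remains open whether a carboxylic acid, a primary amide, an amine or a longer ester chain at the same carbon would move the number in this assay beyond the scatter, or whether every group here would leave it within the scatter. Also unresolved is whether a group at another carbon of this ring, such as a methyl or a chlorine, would behave as ethoxycarbonyl does at this one.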